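Trading fluoro for hydrogen on compound 2

The source may hold more compounds than are shown below. What is called first, only, known or untested is meant among the compounds shown, and "the series" means these compounds.

In a functional assay on HCT-116 cells (Homo sapiens) for inhibition, read by MTT assay, with a stated time of 72 h (a lower number here means a stronger inhibitor, a higher number a weaker inhibitor), compound 1 `COc1cc2c(Oc3ccc(NC(=O)c4nn(-c5ccccc5)cc(C)c4=O)cc3F)ccnc2cc1OCCCC(=O)NO` gives 660 nM and compound 2 `COc1cc2c(Oc3ccc(NC(=O)c4nn(-c5ccccc5F)cc(C)c4=O)cc3F)ccnc2cc1OCCCCCC(=O)NO` gives 590 nM and these two numbers lie within the usual scatter of each other, so neither stands apart. Compound 3 `COc1cc2c(Oc3ccc(NC(=O)c4nn(-c5ccccc5)cc(C)c4=O)cc3F)ccnc2cc1OCCCCCC(=O)NO` differs from compound 2 at one place, described as hydrogen in place of fluoro on an aromatic carbon (hydrogen in place of fluoro on an aromatic carbon, 2-fluorophenyl to phenyl). Among the compounds with values here, no measured pair shows this change alone, so no shift beyond the scatter is expected in this assay, in either direction. The estimated 1.0-fold higher number from compound 2 to compound 3 (0.01 log units; within the scatter) stays within that scatter. Compound 3 is expected to read 600 nM (estimated range 250 nM to 1400 nM).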

Compound 3, half-maximal inhibitory concentration: 690 nM
Compound 3: middle estimate off by 1.2-fold (0.06 log units), on the low side; measured number inside the range.
By their numbers in this assay, from the lowest: compounds 2, 1 and 3 (each within the scatter of the next).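

In this assay, within the data shown here, the first direct reading of hydrogen in place of fluoro on this aromatic carbon, ortho to a large group, is a 1.2-fold higher number from compound 2 to compound 3 (0.07 log units; within the scatter) and so the swap does not separate the two compounds. The chain gives the same picture, with a 1.0-fold higher number from compound 1 to compound 3 (0.02 log units; within the scatter) for 2-(hydroxycarbamoyl)ethyl in place of hydroxycarbamoyl on a saturated chain carbon. No measured evidence bears on either result. Going by these compounds, whether chloro or methoxy on that aromatic carbon, or a longer chain ending in hydroxycarbamoyl, would read apart from these compounds stays open.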